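This account rests on a few compounds, and the source may have more. Where it says the series, first, only, none or still open, it means among the compounds named here.

In a physicochemical assay for solubility (on this read-out higher numbers stand for higher solubility and lower numbers for lower solubility), compound 3 (`O=C(O)c1ccc(C(=O)/C(=C\c2ccc(F)c([N+](=O)[O-])c2)SCc2ccc(F)cc2)cc1`) gives < 1000 ug/mL, which is a limit and not a number. Compound 1 (`O=C(O)c1ccc(C(=O)/C(=C\c2ccc(F)c([N+](=O)[O-])c2)SCc2ccc(Cl)cc2Cl)cc1`) gives < 1000 ug/mL, also a limit. Compound 2 (`O=C(O)c1ccc(C(=O)/C(=C\c2ccc(F)c([N+](=O)[O-])c2)SCc2ccc(C(F)(F)F)cc2)cc1`) gives < 1000 ug/mL, again a limit. Among the measured compounds shown here, the whole series so far therefore rests on (the limit of < 1000 ug/mL in this assay, at which 3 of the 3 values shown sit). Compound 4 (`O=C(O)c1ccc(C(=O)/C(=C\c2ccc(F)c([N+](=O)[O-])c2)SCc2ccccc2)cc1`) has hydrogen in place of fluoro on an aromatic carbon, para to a large group, taking 4-fluorobenzyl to benzyl: hydrogen in place of fluoro on an aromatic carbon. The nearest measured changes offer no size to carry over: a step that the two limits leave unreadable from compound 2 to compound 3, and a step that the two limits leave unreadable from compound 1 to compound 3, with a step that the two limits leave unreadable from compound 1 to compound 2 equally silent. No shift beyond the scatter is expected in this assay, in either direction. The expected change is a step that the limit leaves unreadable from compound 3 to compound 4. For compound 4 the estimate is 400 ug/mL, with an expected range of 50 ug/mL to 1000 ug/mL.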

Compound 4, solubility: < 1000 ug/mL
Compound 4: a limit, no number; the forecaster's own chance of this, stated with the estimate: 85%; the middle value is on the limit's open side.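

No new step can be read in this assay from compound 4 to compound 1, compound 2 or compound 3. Whether these four compounds differ at all in this assay stays open, as the series rests on one limit: the limit of < 1000 ug/mL in this assay, at which 4 of the 4 values shown sit.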